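A few compounds are considered here, and "the series" means these few. Any claim that something is new, unique, unknown or untested is made for them only; others in the source may bear on it.

In a functional assay on HT-29 cells (Homo sapiens) for antiproliferative activity, read by sulforhodamine B assay, with a stated time of 48 h (on this read-out lower numbers stand for stronger inhibition and higher numbers for weaker inhibition), compound 1 `CC(=O)Nc1cccc(S(=O)(=O)Oc2ccccc2C(C)C)c1` gives 27000 nM, while compound 2 `CC(C)C(=O)Nc1cccc(S(=O)(=O)Oc2ccccc2C(C)C)c1` gives 16000 nM. On the numbers at hand compound 2 stands at the lower end, yet the step of a 1.7-fold lower number from compound 1 to compound 2 (0.23 log units; within the scatter) lies within the scatter, so the two cannot be told apart. Compound 3 `CC(C)c1ccccc1OS(=O)(=O)c1cccc(NC(=O)C(C)(C)C)c1` differs from compound 2 by methyl in place of hydrogen on a saturated chain carbon bound to a carbonyl carbon and two saturated chain carbons. Among the measured compounds shown here, only that one step bears on this change, and it was within the scatter, so no step beyond the scatter is expected in this assay. Compound 3 is therefore expected at 13000 nM, between 5000 nM and 32000 nM. This expected step is a 1.2-fold lower number from compound 2 to compound 3 (0.09 log units; within the scatter).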

Compound 3, half-maximal inhibitory concentration: 19000 nM
Beside the measured number, compound 3's estimate is 1.5-fold (0.16 log units) below it, and the stated range covers the measured number.
By their numbers in this assay, from the lowest: compounds 2, 3 and 1 (each within the scatter of the next).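

Methyl in place of hydrogen on this saturated chain carbon gives a 1.2-fold higher number from compound 2 to compound 3 (0.07 log units; within the scatter) in this assay and tert-butyl in place of methyl on the carbonyl carbon gives a 1.4-fold lower number from compound 1 to compound 3 (0.15 log units; within the scatter) on the same read-out. Methyl, isopropyl and tert-butyl on the carbonyl carbon therefore cannot be told apart, and the series now reaches tert-butyl with no step beyond the scatter. Nothing at hand offers an explanation for this result.

Still open, on these data alone, is whether a group of another kind on the carbonyl carbon, such as a phenyl ring or an amine, would give a step beyond the scatter.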